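Benzyl in Place of Hydrogen: a Cytotoxicity Outlook

The source may hold more compounds than are shown below. What is called first, only, known or untested is meant among the compounds shown, and "the series" means these compounds.

Measured compounds:
compound 1 `CCCCCCCCCCCCCCC(NC(=O)OC(C)(C)C)C(=O)O` — "not determined" (no result reported)
compound 2 `CCCCCCCCCCCCCCC(N)CO` — 15.1%

Two compounds were taken into an ADME assay on cells (Splenocyte, Mus musculus, strain BALB/c) for cytotoxicity, read by MTT assay, tested at 1 ug/mL; a lower number here means a weaker effect, a higher number a stronger effect of the compound at the concentration tested. For compound 1 no number was reported, so it contributes nothing to the comparison. In this assay compound 2 gives 15.1%, a weak effect at the concentration tested. For the measured compounds named here, compound 2 therefore stands as the only compound with a number here; there is no second value to rank it against, and no step between measured compounds can be read off.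

Compound 3 `CCCCCCCCCCCCCCC(N)COCc1ccccc1` differs from compound 2 in a single place: benzyl in place of hydrogen on an oxygen on a saturated carbon. Cut one bond further out, the same change reads as hydroxy to benzyloxy.

Going by the values given here, with no measured step to lean on, the size of this change can only be guessed. The step from compound 2 to compound 3 is expected to be small, a number 6.9 percentage points higher from compound 2 to compound 3 (within the scatter), pointing slightly upward but possibly staying within the scatter of repeated measurements. Compound 3 is accordingly expected to give about 22%, with a likely range from 8% to 40%.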

Compound 3, a percentage reported as activity, at one concentration (the size of the read-out at that concentration, not a potency): 0%
Estimate against measurement, compound 3: 22 percentage points above; the measured number lies below the stated range.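

In this assay, for the compounds shown here, the swap of hydroxy to benzyloxy gives a number 15.1 percentage points lower from compound 2 to compound 3 (beyond the scatter) and so supplies the first step in this small set that can be read at all. It shows that this oxygen is not a place where changes pass unnoticed: the weak effect seen with the free hydroxy group does not survive the added benzyl, and compound 3 reads 0% at the one concentration tested. Nothing measured here explains why the read-out falls, so the step stands as an observation without a cause.

The compounds shown leave open whether this loss belongs to benzyl itself or to any group placed on this oxygen, a question that a small methyl group in the same place could begin to answer. They also leave open what a fluorine atom in place of the hydroxy group would do, and whether the effect would return at a higher concentration than the single one used here.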